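Cytotoxicity notes on a thiophene sulfonamide thiourea series

This account rests on a few compounds, and the source may have more. Where it says the series, first, only, none or still open, it means among the compounds named here.

Measured so far:
compound 1, `O=[N+]([O-])c1ccc(NC(=S)NCCNS(=O)(=O)c2ccc(-c3ccccc3O[C@H]3CC[C@@H](O)CC3)s2)cc1`: 20000 nM
compound 2, `COc1ccc(Oc2ccccc2-c2ccsc2S(=O)(=O)N2CCN(C(=S)Nc3ccc([N+](=O)[O-])cc3)CC2)cc1OC`: > 20000 nM

Going by the values given here, in an ADME assay on HEK-293T cells (Homo sapiens) for cytotoxicity, read by CCK-8 assay, with a stated time of 48 h (on this read-out lower numbers stand for stronger inhibition and higher numbers for weaker inhibition), compound 1 gives 20000 nM, the only numerical value in the set. For compound 2 the reading of > 20000 nM is a limit of the assay rather than a number; this is the limit of > 20000 nM in this assay, at which 1 of the 2 values shown sits. Compound 1 therefore stands as the one point that can be placed on the scale.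

Compound 3, `O=[N+]([O-])c1ccc(NC(=S)NCCNS(=O)(=O)c2ccc(-c3ccccc3O[C@H]3CC[C@H](O)CC3)s2)cc1`, remains to be measured. It relates to compound 1 as follows: the two compounds have the same atoms and bonds and differ only in configuration as drawn: 2 of 2 stereo elements differ (all stereocentres are inverted: mirror images); a stereocentre at a saturated ring carbon is drawn s in compound 1 and r in compound 3; a stereocentre at a saturated ring carbon is drawn s in compound 1 and r in compound 3. Among the compounds with values here, no step between measured compounds is available to guide this change. With identical atoms and bonds, the step from compound 1 to compound 3 in this assay is expected to lie within the scatter, in no preferred direction, as no change at the digits printed from compound 1 to compound 3 (within the scatter). Compound 3 is accordingly estimated at 20000 nM, within 10000 nM to 40000 nM.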

Compound 3, half-maximal inhibitory concentration: 10500 nM
Compound 3: the middle estimate sits 1.9-fold (0.28 log units) above what was measured; measured number inside the range.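

In this assay, inverting both stereocentres at the saturated ring carbons gives a 1.9-fold lower number from compound 1 to compound 3 (0.28 log units; within the scatter), so the configuration as drawn does not move the read-out beyond the usual scatter. Going by these compounds alone, this is the first comparison that isolates configuration, and the saturated ring now has two numerical readings instead of one. No other structural change enters this comparison: the fact that compounds 1 and 3 differ only in the configuration as drawn.

Compound 2 remains a limit and not a number, and it offers no numerical comparison: the limit of > 20000 nM in this assay, at which 1 of the 3 values shown sits. As far as these compounds go, whether an amine or a carboxylic acid in place of the hydroxyl on the saturated ring would change the read-out in this assay stays open.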